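The compounds below may be only part of what the source reports. "The series", "measured", "known", "first", "only" and "open" are said of these compounds alone.

Measured compounds:
Compound 1, `O=S(=O)(Nc1ccc(-c2nc3ccccc3o2)cc1)c1ccc(Cl)s1`: > 63000 nM
Compound 2, `O=S(=O)(Nc1ccc2oc(-c3ccccc3)nc2c1)c1ccccc1F`: > 63000 nM

In an assay on isolated protein for inhibition of malate dehydrogenase, mitochondrial (Sus scrofa), with stated times of 45 min and 30 min (on this read-out lower numbers stand for stronger inhibition and higher numbers for weaker inhibition), the value of compound 1 is a limit of the assay and not a number. The value of compound 2 in this assay is likewise a limit and not a number. Both measured values therefore sit at the limit of > 63000 nM in this assay, at which 2 of the 2 values shown sit, so compound 1 stands nowhere in particular among the numbers shown: there is no number for it, only a limit, and the other measured compound is in the same situation.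

Compound 3, `COc1ccccc1S(=O)(=O)Nc1ccc(-c2nc3ccccc3o2)cc1`, has not yet been measured. It differs from compound 1 in one place: 2-methoxyphenyl in place of 5-chlorothiophen-2-yl on a sulfonyl sulfur. For the measured compounds named here, no step between measured compounds is available to size the effect of such a change. As both measured compounds sit at the limit, the step from compound 1 to compound 3 in this assay is expected to be none beyond the scatter, with a real chance that compound 3 again yields only a limit. Compound 3 is estimated at 80000 nM, between 20000 nM and 300000 nM, which means an expected step that the limit leaves unreadable from compound 1 to compound 3.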

Compound 3, half-maximal inhibitory concentration: > 63000 nM
Compound 3 ended at the assay's limit; the forecaster's own chance of this, stated with the estimate: 85%; the middle value is on the limit's open side.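

In this assay compound 3 gives > 63000 nM as a limit of the assay and not a number. Compound 3 and compound 1 thus yield no readable step, and all the compounds shown share one result: the limit of > 63000 nM in this assay, at which 3 of the 3 values shown sit.

What the compounds shown leave open is whether any change on the sulfonyl sulfur alters inhibition in this assay at all.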